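Three Thiocarbamates Without Cytotoxicity and a Fluoro Analogue

The compounds below may be only part of what the source reports. "The series", "measured", "known", "first", "only" and "open" are said of these compounds alone.

compound 1 `O=C(NCCOC(=S)Nc1ccc([N+](=O)[O-])cc1Cl)c1cccnc1` — > 800000 nM
compound 2 `Cc1ccc(NC(=S)OCCNC(=O)c2cccnc2)cc1` — > 800000 nM
compound 3 `CC(C)(Oc1ccc(Cl)cc1)C(=O)Oc1ccc(C(N)=S)cc1` — > 800000 nM

In an ADME assay on WI-38 cells (Homo sapiens) for cytotoxicity, read by MTT assay, with a stated time of 48 h (on this read-out higher numbers stand for weaker inhibition and lower numbers for stronger inhibition), compound 1 gives > 800000 nM, which is a limit of the assay rather than a number. Compound 2 gives > 800000 nM, again a limit. Compound 3 gives > 800000 nM, once more a limit. For the measured compounds named here, compound 2 therefore stands exactly where the other two stand, at the limit of > 800000 nM in this assay, at which 3 of the 3 values shown sit; nothing in the numbers sets it apart from compound 1 or compound 3, and no pair of measured compounds differs in a single place, so no measured step is available to lean on.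

Compound 4 `O=C(NCCOC(=S)Nc1ccc(F)cc1)c1cccnc1` has not yet been measured. It differs from compound 2 by fluoro in place of methyl on an aromatic carbon. Given that compound 2 sits at the limit of > 800000 nM in this assay, at which 3 of the 3 values shown sit, compound 4 is expected to show no step beyond the scatter, an expected step of a number no higher from compound 2 to compound 4 (the limit leaves the size open) in either direction. Compound 4 is accordingly estimated at 800000 nM, with a range from 400000 nM to 1600000 nM, and it is expected that the measurement will most likely come back as a limit of the assay once more rather than as a number.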

Compound 4, half-maximal inhibitory concentration: > 800000 nM
Compound 4: a limit, no number; the forecaster's own chance of this, stated with the estimate: 85%; the middle value lies on the limit itself.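

In this assay compound 4 gives > 800000 nM, which is a limit of the assay and not a number. Compound 2 also stands at a limit, so no step can be read from compound 2 to compound 4. The compounds shown leave open what actual number any of them would give in this assay, since all share one mark: the limit of > 800000 nM in this assay, at which 4 of the 4 values shown sit.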